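A few compounds are considered here, and "the series" means these few. Any claim that something is new, unique, unknown or untested is made for them only; others in the source may bear on it.

Measured so far in a functional assay on HepG2 cells (Homo sapiens) for antiproliferative activity, read by MTT assay, with a stated time of 72 h; on this read-out higher numbers stand for weaker inhibition and lower numbers for stronger inhibition:
- compound 1, `FC(F)(F)c1ccc(COc2ccccc2Nc2ncnc3cc4c(cc23)OCCOCCO4)cc1`, gives only the limit > 100000 nM.
- compound 2, `FC(F)(F)c1ccc(COc2ccc(Nc3ncnc4cc5c(cc34)OCCOCCOCCOCCO5)cc2)cc1`, gives 3340 nM.
- compound 3, `O=[N+]([O-])c1ccc(COc2ccc(Nc3ncnc4cc5c(cc34)OCCOCCOCCOCCO5)cc2)cc1`, gives only the limit > 100000 nM.

Among the measured compounds shown here, the one measured step is from compound 2 to compound 3, the change being (nitro in place of trifluoromethyl on an aromatic carbon). It produced an at least 29-fold higher number from compound 2 to compound 3 (1.47 log units; beyond the scatter), and compound 3 sits at the limit of > 100000 nM in this assay, at which 2 of the 3 values shown sit.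

Compound 4, `O=[N+]([O-])c1ccc(COc2ccccc2Nc2ncnc3cc4c(cc23)OCCOCCO4)cc1`, is not yet measured. It stands to compound 1 as compound 3 stands to compound 2: the change is nitro in place of trifluoromethyl on an aromatic carbon, the same change, the place being worded identically in both cases. How the core of compound 1 differs from the core of compound 2 is not broken down here.

Compound 1 already sits at a limit in this assay. With the measured step pointing toward weaker inhibition, compound 4 is expected to remain at or past that limit, so the step that the limit leaves unreadable from compound 1 to compound 4 is an estimate that cannot be resolved by the assay. The expected value for compound 4 is 300000 nM, within 100000 nM to 1000000 nM, most likely reported again as a limit only.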

Compound 4, half-maximal inhibitory concentration: 50200 nM
The estimate for compound 4 lay 6.0-fold (0.78 log units) above the measured number, outside the stated range (below it).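

In this assay, nitro in place of trifluoromethyl does not carry from one core to the other as a single fixed shift: the same change on two cores in this assay, an at least 29-fold higher number (1.47 log units; beyond the scatter) from compound 2 to compound 3 and an at least 1.9-fold lower number (0.29 log units; that floor lies within the scatter) from compound 1 to compound 4, at least 59-fold (1.77 log units) apart, beyond the scatter of two such steps

Read alone, the new step is an at least 1.9-fold lower number from compound 1 to compound 4 (0.29 log units; that floor lies within the scatter), and two pairs give no rule for any further core, nor do they tell which feature of the cores goes with the split. Compound 1 gives > 100000 nM, a limit and not a number, which leaves the true size of the new step unread.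

The compounds shown leave open how a nitrile or a carboxylic acid in the same place would read on each of the two cores, and whether either would follow compound 3 or compound 4. They also leave open which part of the difference between the core of compound 1 and the core of compound 2 goes with the split, a question that needs pairs differing in that one part alone.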